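Replacing the benzoyl bridge with other one-atom linkers

This account rests on a few compounds, and the source may have more. Where it says the series, first, only, none or still open, it means among the compounds named here.

Compound 1 `CCS(=O)(=O)N(Cc1cccnc1)c1ccc(C(=O)c2ccccc2)cc1` gives 4200 nM in an assay on isolated protein with metabotropic glutamate receptor 2 (Homo sapiens) as the target; on this read-out lower numbers stand for an effect already at smaller amounts and higher numbers for an effect only at larger amounts of compound. Compound 2 `CCS(=O)(=O)N(Cc1cccnc1)c1ccc(C(F)c2ccccc2)cc1` reaches only the assay limit in this assay, at > 30000 nM. The step of an at least 7.1-fold higher number from compound 1 to compound 2 (0.85 log units; beyond the scatter) is bounded by the limit of > 30000 nM in this assay, at which 1 of the 2 values shown sits. Compound 3 `CCS(=O)(=O)N(Cc1cccnc1)c1ccc(COc2ccccc2)cc1` carries phenoxymethyl in place of fluoro(phenyl)methyl on an aromatic carbon. Within the data shown here, the only measured step at this position is an at least 7.1-fold higher number from compound 1 to compound 2 (0.85 log units; beyond the scatter), and since phenoxymethyl, like fluoro(phenyl)methyl, lacks the carbonyl of compound 1, compound 3 is expected to stay weak, with a number no higher from compound 2 to compound 3 (the limit leaves the size open) not beyond the scatter. Compound 3 is estimated at 30000 nM, between 8000 nM and 100000 nM.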

Compound 3, half-maximal effective concentration: 2100 nM
For compound 3 the middle estimate is 14-fold (1.15 log units) above the measured one; the measured number lies below the stated range.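

Loss of the carbonyl does not by itself cost activity at this position: phenoxymethyl also lacks it, yet the change from benzoyl gives a 2.0-fold lower number from compound 1 to compound 3 (0.30 log units; within the scatter). The other carbonyl-free group, fluoro(phenyl)methyl, falls well short of phenoxymethyl, with an at least 14-fold lower number from compound 2 to compound 3 (1.15 log units; beyond the scatter), so the outcome depends on the linker atoms and not on the carbonyl alone. The size of that step stays open, as compound 2 stands at a limit of the assay: the limit of > 30000 nM in this assay, at which 1 of the 3 values shown sits.

Whether the oxygen of phenoxymethyl itself accounts for the difference remains open. A 2-phenylethyl group, with carbon in place of that oxygen, or an anilinomethyl group, with an amine nitrogen there, would separate the atom from the linker length.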